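This account rests on a few compounds, and the source may have more. Where it says the series, first, only, none or still open, it means among the compounds named here.

Measured so far:
compound 1, `COc1nc(C)c(Nc2nc(Cl)cn([C@H](COC(=O)c3ccccn3)C3CC3)c2=O)cc1C`, 67 nM
compound 2, `COc1nc(C)c(Nc2nc(Cl)cn([C@H](COC(=O)Nc3ccccc3)C3CC3)c2=O)cc1C`, 1.5 nM

On an assay on frontal cortex for displacement of a labelled ligand from corticotropin-releasing factor receptor 1 (Rattus norvegicus), with a stated time of 2 h (on this read-out lower numbers stand for stronger inhibition and higher numbers for weaker inhibition), compound 1 gives 67 nM, the highest of the two numbers shown; the nearest is compound 2, which gives 1.5 nM, reached by a 45-fold lower number from compound 1 to compound 2 (1.65 log units; beyond the scatter). Compound 3, `COc1nc(C)c(Nc2nc(Cl)cn([C@H](COc3cc(Br)ccn3)C3CC3)c2=O)cc1C`, is not yet measured. It differs from compound 1 by 4-bromopyridin-2-yl in place of (pyridin-2-yl)carbonyl on an oxygen on a saturated carbon. Among the measured compounds shown here, no measured step matches this change: the one step known, from compound 1 to compound 2, alters the group on the carbonyl carbon while the carbonyl itself remains, whereas here the whole (pyridin-2-yl)carbonyl leaves and a 4-bromopyridin-2-yl sits directly on the oxygen on a saturated carbon. That single step does show that this part of the molecule moves the number a great deal, so a step beyond the scatter in this assay is plausible, but the measured compounds give no firm ground for its direction. Compound 3 is therefore expected to give about 20 nM, within 3 nM to 150 nM, an expected step of a 3.4-fold lower number from compound 1 to compound 3 (0.53 log units; beyond the scatter) that leans toward a lower number while leaving room for a number above that of compound 1.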

Compound 3, half-maximal inhibitory concentration: 1.5 nM
Estimate against measurement, compound 3: 13-fold (1.12 log units) above; the whole stated range lies above it.
By their numbers in this assay, from the lowest: compounds 2 and 3 (each within the scatter of the next); then compound 1.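

In this assay, putting 4-bromopyridin-2-yl in place of (pyridin-2-yl)carbonyl on the oxygen on a saturated carbon gives a 45-fold lower number from compound 1 to compound 3 (1.65 log units; beyond the scatter), so a carbonyl at this place is not needed for a number this low. Putting the same group in place of phenylcarbamoyl gives no change at the digits printed from compound 2 to compound 3 (within the scatter), so two groups with quite different links to that oxygen read alike here, and among the three compounds only the (pyridin-2-yl)carbonyl group stands apart. No evidence at hand bears on why these groups read as they do.

On these data alone, the step to compound 3 removes the carbonyl and brings in the bromine in one change, so the share of each in that step stays open, and a plain pyridin-2-yl placed directly on the oxygen would be the compound to separate them. Also open, as far as these compounds go, is how far this place tolerates other groups on that oxygen, such as 4-chloropyridin-2-yl, 4-methoxypyridin-2-yl or a plain phenyl, or a bare hydroxyl on the saturated carbon.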